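Swapping the ring amine on compound 2

The source may hold more compounds than are shown below. What is called first, only, known or untested is meant among the compounds shown, and "the series" means these compounds.

Compound 2 `CC(O)(C#Cc1ccc(N2CCCC2)c(Nc2ncnc3[nH]ccc23)c1)c1nccs1` gives 107 nM in an assay for inhibition of mitogen-activated protein kinase kinase kinase 14 (Homo sapiens), read by luminescence and ADP-Glo, with a stated time of 120 min, in the presence of a further agent that is not named here (a higher number here means a weaker inhibitor, a lower number a stronger inhibitor), the lowest of the two numbers seen so far; compound 1 `CN(C)CCN(C)c1ccc(C#CC(C)(O)c2nccs2)cc1Nc1ncnc2[nH]ccc12` gives 484 nM. Compound 3 `C[C@@H]1CN(c2ccc(C#CC(C)(O)c3nccs3)cc2Nc2ncnc3[nH]ccc23)CCN1` differs from compound 2 in one place: 3-methylpiperazin-1-yl in place of pyrrolidin-1-yl on an aromatic carbon. Among the compounds with values here, the only step that touches this position is the one from compound 1 to compound 2, where the amine was exchanged and a 4.5-fold lower number from compound 1 to compound 2 (0.66 log units; beyond the scatter) followed. Since that change brought a modest gain, another exchange of the same group is expected to move this assay only modestly in either direction, so compound 3 is estimated at 150 nM with a range of 45 nM to 500 nM, an expected step of a 1.4-fold higher number from compound 2 to compound 3 (0.15 log units; within the scatter).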

Compound 3, half-maximal inhibitory concentration: 210 nM
Estimate against measurement, compound 3: 1.4-fold (0.15 log units) below; low and high end bracket the measured number.
By their numbers in this assay, from the lowest: compounds 2 and 3 (each within the scatter of the next); then compound 1.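

In this assay, a six-membered ring with 2 hetero atoms and a defined stereocentre serves this aromatic carbon as well as the five-membered pyrrolidin-1-yl, as far as the scatter can tell (a 2.0-fold higher number from compound 2 to compound 3 (0.29 log units; within the scatter)). The 3-methylpiperazin-1-yl group also keeps an edge over the open (2-(dimethylamino)ethyl)(methyl)amino chain (a 2.3-fold lower number from compound 1 to compound 3 (0.36 log units; beyond the scatter)), so both ring amines shown give lower numbers than that chain. Nothing available explains these differences. Still open, from the compounds shown here alone, is how piperazin-1-yl without the methyl group, the opposite methyl stereoisomer, or morpholin-4-yl would compare here.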